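Oxime ether series on the shared core: toward the free oxime

The source may report more compounds than this note shows. Statements on the series, on what has been measured and on what is new or still open speak of the compounds shown alone.

Measured in a functional assay on HCT-116 cells (Homo sapiens) for antiproliferative activity; a higher number here means a weaker inhibitor, a lower number a stronger inhibitor:
compound 1 `CO/N=C/c1c(N)ncnc1Oc1ccc2cccnc2c1` gives 2620 nM
compound 2 `COCCO/N=C/c1c(N)ncnc1Oc1ccc2[nH]c(C)cc2c1F` gives 387 nM
compound 3 `CO/N=C/c1c(N)ncnc1Oc1ccc2[nH]cc(C)c2c1` gives 385 nM

Compound 2 sits second highest of the three numbers in this assay. Its nearest neighbour is compound 3, whose value lies within the scatter of that of compound 2, so no order between the two can be read. Compound 1 stands furthest away, with a value beyond the scatter of compound 2.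

Compound 4 `Cc1cc2c(F)c(Oc3ncnc(N)c3/C=N/O)ccc2[nH]1` is not yet measured. It differs from compound 2 by hydrogen in place of 2-methoxyethyl on an oxygen. Among the measured compounds shown here, no measured pair shows this change, so the step is open. A small weakening is expected at most, with the step from compound 2 to compound 4 estimated as a 1.6-fold higher number from compound 2 to compound 4 (0.19 log units; within the scatter), within the scatter. For compound 4 the estimate is 600 nM, range 200 nM to 1800 nM.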

Compound 4, half-maximal inhibitory concentration: 1140 nM
Compound 4: middle estimate off by 1.9-fold (0.28 log units), on the low side; the measured number falls inside the stated range.
By their numbers in this assay, from the lowest: compounds 3 and 2 (each within the scatter of the next); then compound 4; then compound 1.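

In this assay, hydrogen in place of 2-methoxyethyl on the oxygen bonded to the double-bonded nitrogen gives a 2.9-fold higher number from compound 2 to compound 4 (0.47 log units; beyond the scatter). Among the compounds shown here, this is the first readable step at this position, and it shows that on this core the position is not indifferent to the change, with the 2-methoxyethoxy form ahead of the hydroxy form. Nothing available explains the difference.

Open, going by these compounds, is whether a plain methyl on this oxygen of the core of compound 2 would track compound 2 or compound 4. Also open, on these data alone, is how a longer chain or a chain ending in an amine would read.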